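Notes on compound 3: 3-bromophenyl for 4-methoxyphenyl

A few compounds are considered here, and "the series" means these few. Any claim that something is new, unique, unknown or untested is made for them only; others in the source may bear on it.

In a functional assay on MGC-803 cells (Homo sapiens) for inhibition, read by MTT assay, with a stated time of 72 h (on this read-out lower numbers stand for stronger inhibition and higher numbers for weaker inhibition), compound 1 `CCCCc1ccc(NC(=O)C2CCN(C/C=C/c3ccccc3)CC2)cc1` gives 2570 nM and compound 2 `COc1ccc(NC(=O)C2CCN(C/C=C/c3ccccc3)CC2)cc1` gives 58200 nM. For the measured compounds named here, compound 2 therefore holds the higher of the only two numbers available, and so the weaker inhibition. The next structure is compound 3 `O=C(Nc1cccc(Br)c1)C1CCN(C/C=C/c2ccccc2)CC1`, which differs from compound 2 as follows: 3-bromophenyl in place of 4-methoxyphenyl on an amide-type nitrogen. Going by the values given here, one measured step bears on this change: a 23-fold higher number from compound 1 to compound 2 (1.35 log units; beyond the scatter), a large step beyond the scatter, with methoxy in place of butyl on an aromatic carbon. Among the compounds with values here, it shows that the read-out can move strongly with the group carried on this aromatic ring, but no bromine-bearing compound has been measured. A lower number is expected, with a smaller shift than the measured one, and the expected step is a 5.3-fold lower number from compound 2 to compound 3 (0.72 log units; beyond the scatter). For compound 3 the estimate is 11000 nM, with an expected range of 2500 nM to 40000 nM.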

Compound 3, half-maximal inhibitory concentration: 9110 nM
For compound 3 the middle estimate is 1.2-fold (0.08 log units) above the measured one, within the range that was stated.
By their numbers in this assay, from the lowest: compound 1; then compound 3; then compound 2.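

In this assay the 4-methoxyphenyl on the amide-type nitrogen can be replaced with a gain in inhibition even without a butyl group: 3-bromophenyl gives a 6.4-fold lower number from compound 2 to compound 3 (0.81 log units; beyond the scatter) as a modest step beyond the scatter. The weak reading of compound 2 is therefore not common to every substituted phenyl on this nitrogen. As the group names show, the substituent and its ring position change together, so the step belongs to the whole change and cannot be assigned to the bromine alone. No measurement that would explain the step is at hand.

As far as these compounds go, whether the step follows the bromine or the ring position stays open. Also open, from the compounds shown here alone, is how a chlorine, an amine or a carboxylic acid in place of the bromine would read on this series.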